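Diamine series: fluorophenyl to dichlorophenyl on the sulfur

The source may report more compounds than this note shows. Statements on the series, on what has been measured and on what is new or still open speak of the compounds shown alone.

Measured compounds:
Compound 1 `CCOC(=O)[C@H](CCC(=O)O)NC(=O)c1ccc(Sc2nc3cc(N)cc(N)c3nc2-c2ccccc2)cc1` gives 7940 nM in a functional assay on MDA-MB-231 cells (Homo sapiens) for inhibition, read by sulforhodamine B assay, with a stated time of 48 h; on this read-out lower numbers stand for stronger inhibition of growth and higher numbers for weaker inhibition of growth.
Compound 2 `Nc1cc(N)c2nc(-c3ccccc3)c(Sc3ccc(F)cc3)nc2c1` gives 17400 nM in this assay.
Compound 3 `COc1cc(CNc2nc3cc(N)cc(N)c3nc2-c2ccccc2)cc(OC)c1OC` gives 7240 nM in this assay.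

Compound 2 stands at the highest of the three numbers. Its nearest neighbour is compound 1, whose number is lower by a margin beyond the scatter; compound 3 lies a little further below, also beyond the scatter. Compound 2 is thus the weakest growth inhibitor of the three, though both gaps are small.

Compound 4 `Nc1cc(N)c2nc(-c3ccccc3)c(Sc3ccc(Cl)c(Cl)c3)nc2c1` is a variant of compound 2 changed in one place: 3,4-dichlorophenyl in place of 4-fluorophenyl on a sulfur. The new group keeps the ring on the sulfur whose other neighbour is aromatic carbon; donors, acceptors and charge are unchanged.

Going by the values given here, no pair among the measured compounds reports this kind of step, and compound 1 and compound 3 differ from compound 2 at other places, so nothing measured here speaks directly to it. The expectation is a small step, likely towards a lower number but not clearly beyond the scatter: the step from compound 2 to compound 4 is expected to be a 1.5-fold lower number from compound 2 to compound 4 (0.16 log units; within the scatter). For compound 4 the estimated value is 12000 nM, with a range from 5000 nM to 30000 nM.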

Compound 4, concentration for 50% growth inhibition: 16600 nM
For compound 4 the middle estimate is 1.4-fold (0.14 log units) below the measured one; the range from low to high includes it.
By their numbers in this assay, from the lowest: compounds 3 and 1 (each within the scatter of the next); then compounds 4 and 2 (each within the scatter of the next).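

In this assay, 3,4-dichlorophenyl in place of 4-fluorophenyl on a sulfur gives a 1.0-fold lower number from compound 2 to compound 4 (0.02 log units; within the scatter), so the two compounds cannot be told apart on growth inhibition. This is the first step in the series that can be read directly at this place, since the earlier compounds differed from compound 2 without a listed one-place step. Here, the exchange of a single fluorine for two chlorines on the phenyl ring leaves the read-out within the scatter, and nothing available on the properties of these compounds accounts for that result.

A single step cannot show whether the phenyl ring on the sulfur is insensitive to substitution in general or only to halogen exchange, so a nitrile or a trifluoromethyl group on that ring would be the more informative comparison. Also open, going by these compounds, is how the read-out responds when the ring itself gives way to a longer alkyl chain on the sulfur, with the rest of the core of compound 2 kept unchanged.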